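The source may report more compounds than this note shows. Statements on the series, on what has been measured and on what is new or still open speak of the compounds shown alone.

Four compounds share one core, and the question is how much of each a hamster kidney cell line can tolerate. Compound 1 `O=C(CCSc1nnc(-c2ccncc2)s1)Nc1c(Cl)cccc1Cl` carries a 2,6-dichlorophenyl group on the amide; in an ADME assay on BHK-21 cells (Mesocricetus auratus) for cytotoxicity, with a stated time of 3 days (a higher number here means that more compound is tolerated, a lower number that less compound is tolerated), compound 1 gives 10300 nM. Compound 2 `O=C(CCSc1nnc(-c2ccncc2)s1)Nc1ccccc1Cl` differs by one change, (hydrogen in place of chloro on an aromatic carbon). In this assay compound 2 reports only a limit, > 50000 nM. The step is an at least 4.8-fold higher number from compound 1 to compound 2 (0.68 log units; beyond the scatter), which rests on the limit of > 50000 nM in this assay, at which 1 of the 3 values shown sits, rather than on a measured number.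

Compound 3 `O=C(CSc1nnc(-c2ccncc2)s1)Nc1c(Cl)cccc1Cl` has a shorter chain between the amide and the sulfur; the difference between its core and the core of compound 1 is not broken down here. For compound 3 the result in this assay reads "not determined" (no result reported). Compound 4 `O=C(CSc1nnc(-c2ccncc2)s1)Nc1ccccc1Cl` stands to compound 3 as compound 2 stands to compound 1, (hydrogen in place of chloro on an aromatic carbon); it is the same change, made twice in all among these compounds, and each time it replaces the second chloro on the aromatic ring with hydrogen.

Because the step from compound 1 to compound 2 reached the assay ceiling (the limit of > 50000 nM in this assay, at which 1 of the 3 values shown sits), the same change on the shorter-chain core is expected to move in the same direction, with the caveat that compound 3 itself offers no starting number. On that basis compound 4 is expected to give 50000 nM in this assay, with an estimated range from 15000 nM to 120000 nM.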

Compound 4, half-maximal cytotoxic concentration: > 50000 nM
Compound 4 gave a limit, no number (the forecaster's own chance of this, stated with the estimate: 60%); the middle value lies on the limit itself.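

In this assay compound 4 reports only > 50000 nM as a limit, not a number. For the compounds shown here, compound 3 has no result to set against it, so no step from compound 3 to compound 4 can be read. The compounds shown leave open whether the shorter chain changes how much compound the cells tolerate, as compound 2 and compound 4 both rest on one ceiling: the limit of > 50000 nM in this assay, at which 2 of the 4 values shown sit.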